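From Bromo to Chloro at a Measuring Limit

This account rests on a few compounds, and the source may have more. Where it says the series, first, only, none or still open, it means among the compounds named here.

Compound 1 (`CCOC(=O)CCCCCOc1cccc(CN(C(=O)c2ccc(-c3cccc(-c4ccccc4)c3)cc2)C(C)C)c1`) carries a phenyl group where compound 2 (`CCOC(=O)CCCCCOc1cccc(CN(C(=O)c2ccc(-c3cccc(Br)c3)cc2)C(C)C)c1`) carries bromo, and both were tested in an ADME assay on BJ cells (Homo sapiens) for cytotoxicity, read by CellTiter-Glo and resazurin assay, with a stated time of 72 h; a higher number here means that more compound is needed for the effect, a lower number that less compound is needed. Compound 1 gives > 26000 nM, which is a limit and not a number. Compound 2 gives > 26000 nM, which is also a limit. Both measured compounds therefore share one reading: the limit of > 26000 nM in this assay, at which 2 of the 2 values shown sit.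

For the measured compounds named here, the only measured step, a step that the two limits leave unreadable from compound 1 to compound 2, has no readable size, so it offers no number to carry forward. Going by the values given here, it shows only that both compounds end at the same limit.

Compound 3 (`CCOC(=O)CCCCCOc1cccc(CN(C(=O)c2ccc(-c3cccc(Cl)c3)cc2)C(C)C)c1`) has chloro in place of bromo on an aromatic carbon. The rest of the molecule stays the same. Among the compounds with values here, with no measured step of known size to draw on, the expectation rests on compound 2 at > 26000 nM and on this single-atom exchange. The expected change, a number no higher from compound 2 to compound 3 (the limit leaves the size open), is none beyond the usual scatter, in either direction. For compound 3 the estimate is 26000 nM, with an expected range of 13000 nM to 52000 nM, and the assay will most likely report only a limit again.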

Compound 3, half-maximal effective concentration: > 18400 nM
Compound 3 ended at the assay's limit; the forecaster's own chance of this, stated with the estimate: 85%; the middle value does not contradict the limit.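

In this assay compound 3 gives > 18400 nM, which is a limit and not a number. The steps linking compound 1, compound 2 and compound 3 all end at limits, so none of them can be read. The compounds shown leave open what concentration each needs for the effect, and whether phenyl, bromo and chloro differ at all.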